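A few compounds are considered here, and "the series" means these few. Any claim that something is new, unique, unknown or untested is made for them only; others in the source may bear on it.

- Compound 1 `Cc1ccc(NC(=S)N/N=C/c2ccc3ccccc3n2)cc1`: 92900 nM
- Compound 2 `S=C(N/N=C/c1ccc2ccccc2n1)Nc1ccccc1Br`: > 100000 nM

In a functional assay on SGC-7901 cells (Homo sapiens) for antiproliferative activity, read by sulforhodamine B assay, with a stated time of 72 h (on this read-out lower numbers stand for stronger inhibition and higher numbers for weaker inhibition), compound 2 gives > 100000 nM, which is a limit of the assay and not a number. Compound 3 `Fc1cccc(NC(=S)N/N=C/c2ccc3ccccc3n2)c1` differs from compound 2 on an amide-type nitrogen: 3-fluorophenyl in place of 2-bromophenyl on an amide-type nitrogen. Among the measured compounds shown here, the one measured step that bears on this change, an at least 1.0-fold higher number from compound 1 to compound 2 (0.03 log units; that floor lies within the scatter), alters the group on that same nitrogen, yet gives only a floor within the scatter. The expected step is therefore none beyond the scatter: an at least 1.2-fold lower number from compound 2 to compound 3 (0.09 log units; that floor lies within the scatter). For compound 3 the estimated value in this assay is 80000 nM, with an expected range of 30000 nM to 100000 nM.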

Compound 3, half-maximal inhibitory concentration: 79900 nM
Compound 3: the middle estimate sits 1.0-fold (0.00 log units) above what was measured; measured number inside the range.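

In this assay, 3-fluorophenyl on the amide-type nitrogen gives a firm number for a second group, yet the comparison with 4-methylphenyl shows no real shift: a 1.2-fold lower number from compound 1 to compound 3 (0.07 log units; within the scatter). Compound 2 gives > 100000 nM, which is a limit of the assay and not a number. The other step, an at least 1.2-fold lower number from compound 2 to compound 3 (0.09 log units; that floor lies within the scatter), is therefore only a floor, and no difference beyond the scatter can be read from it, because of this limit: the limit of > 100000 nM in this assay, at which 1 of the 3 values shown sits.

All three compounds carry a substituted phenyl group here. On these data alone, whether an aminophenyl, a carboxylic acid or a longer alkyl chain on this nitrogen would move the number stays open.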